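This account rests on a few compounds, and the source may have more. Where it says the series, first, only, none or still open, it means among the compounds named here.

Compound 1 `N/N=C1\NCCN1c1ccccc1Cl`: 22%
Compound 2 `N/N=C1\NCCN1c1ccccc1`: 0%
Compound 3 `N=c1c(=O)[nH]nc2n1CCN2c1ccccc1`: 0%

These three compounds were tested in a functional assay on T47D cells (Homo sapiens) for cytotoxicity, with a stated time of 72 h, tested at 10 ug/mL; on this read-out lower numbers stand for a weaker effect and higher numbers for a stronger effect at the one concentration tested. Compound 1 and compound 2 share one core, and the change chloro in place of hydrogen on an aromatic carbon gave a number 22 percentage points higher from compound 2 to compound 1 (beyond the scatter). Compound 3 has a different core; how the cores of compound 2 and compound 3 differ is not broken down here. In this assay compound 3 gives 0%, level with compound 2.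

Compound 4 `N=c1c(=O)[nH]nc2n1CCN2c1ccc(Cl)cc1` is to be measured. It differs from compound 3 by chloro in place of hydrogen on an aromatic carbon. This is the same kind of change as in compound 1, not the same: in compound 1 the chloro is ortho to a group of 7 heavy atoms, in compound 4 it is para to a large group.

Because compound 3 sits at 0% and the earlier chloro step was a number 22 percentage points higher from compound 2 to compound 1 (beyond the scatter), a step of about a number 12 percentage points higher from compound 3 to compound 4 (beyond the scatter) is expected, giving an estimate for compound 4 of 12%, between 0% and 30%.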

Compound 4, a percentage reported as inhibition, at one concentration (the size of the read-out at that concentration, not a potency): 16%
Beside the measured number, compound 4's estimate is 4 percentage points below it; the measured number falls inside the stated range.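

In this assay, chloro in place of hydrogen gave a number 16 percentage points higher from compound 3 to compound 4 (beyond the scatter). The step on this core matches the earlier one in direction, and the two do not differ in size: the same change on two cores in this assay, a number 22 percentage points higher (beyond the scatter) from compound 2 to compound 1 and a number 16 percentage points higher (beyond the scatter) from compound 3 to compound 4, 6 percentage points apart, within the scatter of two such steps

This does not show that the change carries over unaltered, as in compound 4 the chloro is para to a large group and in compound 1 it sits elsewhere on the ring, so core and place change together, and a single concentration gives no potency. 

Open, going by these compounds, is whether chloro at one and the same place on both cores gives matching steps. Also open, on these data alone, is how a methoxy, an amine or a carboxylic acid on this ring would compare.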